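The source may hold more compounds than are shown below. What is called first, only, known or untested is meant among the compounds shown, and "the series" means these compounds.

In a toxicity assay on the whole organism (strain Icem-CET (SPF Caw)) for cytotoxicity, with Mus musculus as the target (a higher number here means that more compound is needed for the effect, a lower number that less compound is needed), three compounds have been measured so far:
compound 1, `COc1ccc(/C(C)=C(/C)C(=O)NC2CC2)cc1`, gives 300 mg/kg;
compound 2, `C=CCNC(=O)/C(C)=C(\C)c1ccc(Br)cc1`, gives 500 mg/kg;
compound 3, `C#CCNC(=O)/C(C)=C(\C)c1ccc(OC)cc1`, gives 150 mg/kg.

The number for compound 1 lies between those of compound 2 and compound 3, and all three numbers lie within the usual scatter of repeated measurements of one another, so no ordering among the three can be read from them. Compound 4, `C/C(C(=O)NC1CC1)=C(\C)c1ccccc1`, has not yet been measured in this assay. It differs from compound 1 in one place: hydrogen in place of methoxy on an aromatic carbon. Within the data shown here, no pair of measured compounds shows the effect of such a change, so there is nothing to set its size from directly. With the three measured numbers so close together despite their differing groups, the expectation is that the step from compound 1 to compound 4 stays within the scatter, no change at the digits printed from compound 1 to compound 4 (within the scatter), with no preferred direction. Compound 4 is therefore expected to give about 300 mg/kg, within a range from 150 mg/kg to 600 mg/kg.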

Compound 4, dose for half-maximal effect: 300 mg/kg
For compound 4 middle estimate and measured number coincide at the digits printed; measured number inside the range.
By their numbers in this assay, from the lowest: compounds 3, 1, 4 and 2 (each within the scatter of the next, the first and the last beyond it).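

Putting hydrogen in place of methoxy on this aromatic carbon, para to a large group, gives no change at the digits printed from compound 1 to compound 4 (within the scatter) in this assay. The earlier compounds shown here each differed from one another in more than one place, whereas this pair isolates a single position: on the core of compound 1, the methoxy group, with its 2 heavy atoms and hydrogen-bond acceptor, can be removed without a change that this assay can resolve. Nothing here explains this result.

On these data alone, whether this position tolerates other groups in the same way remains open, for example an amine or a carboxylic acid on the same carbon. As far as these compounds go, it is also open whether the same exchange would leave the number unchanged with a longer chain on the amide nitrogen.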